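A Smaller Alkenyl Group on the Alkyne of Compound 2

This account rests on a few compounds, and the source may have more. Where it says the series, first, only, none or still open, it means among the compounds named here.

Measured so far:
Compound 1, `CC(C)=C(C)C#Cc1ccc(CCC(=O)O)cc1`: 105%
Compound 2, `C/C=C(/C)C#Cc1ccc(CCC(=O)O)c(F)c1`: 103%

Among the compounds with values here, only two compounds have been measured. In a functional assay on 1321-N1 cells for agonist activity at Free fatty acid receptor 1 (Homo sapiens), read by calcium flux, with a stated time of 0.4 s (on this read-out higher numbers stand for larger maximal responses and lower numbers for smaller maximal responses), compound 1 reaches 105%, and compound 2 reaches 103%. Compound 2 holds the lower of the two numbers, but its gap to compound 1 lies within the scatter, so the two cannot be told apart; both give essentially the full response of the reference.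

Compound 3, `C/C=C\C#Cc1ccc(CCC(=O)O)c(F)c1`, remains to be measured in this assay. It differs from compound 2 in one place: prop-1-en-1-yl in place of 1-methylprop-1-en-1-yl on a triple-bonded carbon. Within the data shown here, no step between two measured compounds matches this change, so there is nothing measured to weigh it by. Because compound 1 at 105% and compound 2 at 103% both sit near the full response, a shift beyond the scatter is not expected, though a modest drop cannot be ruled out. Compound 3 is expected to give 97% (range 78% to 112%). The step of a number 6 percentage points lower from compound 2 to compound 3 (within the scatter) is thus expected to stay within the scatter.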

Compound 3, largest response reached (reported as efficacy), in percent of the reference or control that the assay uses: 91%
For compound 3 the middle estimate is 6 percentage points above the measured one; measured number inside the range.
By their numbers in this assay, from the lowest: compound 3; then compounds 2 and 1 (each within the scatter of the next).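

In this assay, within the data shown here, a maximal response a number 12 percentage points lower from compound 2 to compound 3 (beyond the scatter) gives the first change in this set that stands clear of the scatter. It shows that the group on the triple-bonded carbon is not a freely interchangeable part of the structure: going from 1-methylprop-1-en-1-yl, with 4 heavy atoms, to prop-1-en-1-yl, with 3, is enough to lower the response, although the change is modest and compound 3 remains a clear agonist. Among these compounds, nothing available explains this drop and the single step gives no trend.

The compounds shown leave open how a saturated propyl chain or a cyclopropyl group on the same triple-bonded carbon would compare with these alkenyl groups. They also leave open whether the same exchange would lower the response on the core of compound 1.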